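The source may hold more compounds than are shown below. What is called first, only, known or untested is meant among the compounds shown, and "the series" means these compounds.

Compound 1 `CCCS(=O)(=O)Nc1ccc(F)c(C(=O)c2n[nH]c3ncc(-c4ccc(N(C)C)cc4)cc23)c1F` sits lowest of the two numbers in hand: in an assay for binding affinity to dual specificity mitogen-activated protein kinase kinase 4 (Homo sapiens), read by KINOMEscan, tested at 100 nM (a higher number here means a weaker effect of the compound at the concentration tested, a lower number a stronger effect), compound 1 gives 2.5%. Compound 2 `CCCS(=O)(=O)Nc1ccc(F)c(C(=O)c2n[nH]c3ncc(-c4ccc(Cl)cc4Cl)cc23)c1F` gives 22% in this assay, and the step of a number 19.5 percentage points higher from compound 1 to compound 2 (beyond the scatter) is the only one measured at this position, a modest rise on swapping the aryl group on the shared core. Compound 3 `CCCS(=O)(=O)Nc1ccc(F)c(C(=O)c2n[nH]c3ncc(-c4ccc(S(=O)(=O)NC(C)=O)cc4)cc23)c1F` changes compound 1 by acetylsulfamoyl in place of dimethylamino on an aromatic carbon. That single step bears only loosely on the new change, so a rise of similar or smaller size is expected, a number 12.5 percentage points higher from compound 1 to compound 3 (beyond the scatter). Compound 3 is estimated at 15% in this assay, between 2% and 45%.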

Compound 3, a percentage reported as activity, at one concentration (the size of the read-out at that concentration, not a potency): 0.35%
The estimate for compound 3 lay 14.7 percentage points above the measured number; the measured number lies below the stated range.
By their numbers in this assay, from the lowest: compounds 3 and 1 (each within the scatter of the next); then compound 2.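

Replacing dimethylamino with acetylsulfamoyl gives a number 2.2 percentage points lower from compound 1 to compound 3 (within the scatter) in this assay, so on the shared core this place takes either group without a step beyond the scatter. The rise of a number 19.5 percentage points higher from compound 1 to compound 2 (beyond the scatter) is therefore not repeated by this second replacement, which brings in more heavy atoms and a hydrogen-bond donor. Nothing at hand explains why the two groups read alike. Still open, on these data alone, is whether the acetyl part matters, which an unsubstituted sulfonamide would test. As far as these compounds go, a carboxylic acid or a morpholine at this place also remains untested here.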